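A Larger Group on a Compound at the Limit

This account rests on a few compounds, and the source may have more. Where it says the series, first, only, none or still open, it means among the compounds named here.

Compound 1 `C#Cc1cccc(Nc2nc3cnc(Nc4ccc(N5CCN(C)CC5)cc4)nc3n2C2CCCC2)c1`: < 0.01 nM (a limit)
Compound 2 `CN1CCN(c2ccc(Nc3ncc4nc(Nc5cccc(Cl)c5)n(C5CCCC5)c4n3)cc2)CC1`: < 0.01 nM (a limit)

Both entries come from a functional assay on HCC827 cells (Homo sapiens) for cytotoxicity, read by MTT assay, with a stated time of 72 h (on this read-out lower numbers stand for stronger inhibition and higher numbers for weaker inhibition), and neither is a number. Among the compounds with values here, compound 2 stands only at a limit, and the series so far offers just this: the limit of < 0.01 nM in this assay, at which 2 of the 2 values shown sit (no value sits clear of it). Compound 3 `CN1CCN(c2ccc(Nc3ncc4nc(Nc5cccc(C(=O)Nc6ccc(Cl)cc6)c5)n(C5CCCC5)c4n3)cc2)CC1` differs from compound 2 by one change, (4-chlorophenyl)carbamoyl in place of chloro on an aromatic carbon. Within the data shown here, the one measured step at this place (a step that the two limits leave unreadable from compound 1 to compound 2) gives no size to carry over. The entering group is much the larger one, so a weakening in this assay is expected, though its size remains highly uncertain. The step expected here is a weakening (an at least 20-fold higher number from compound 2 to compound 3 (1.30 log units; beyond the scatter)). Compound 3 is estimated at 0.2 nM (expected range 0.01 nM to 5 nM).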

Compound 3, half-maximal inhibitory concentration: 2900 nM
The estimate for compound 3 lay 15000-fold (4.16 log units) below the measured number; the measured number lies above the stated range.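

In this assay, the place that carried ethynyl in compound 1 and chloro in compound 2 proves far from indifferent to what it holds: (4-chlorophenyl)carbamoyl in place of chloro gives an at least 290000-fold higher number from compound 2 to compound 3 (5.46 log units; beyond the scatter), and the same group in place of ethynyl gives an at least 290000-fold higher number from compound 1 to compound 3 (5.46 log units; beyond the scatter). The step between compound 1 and compound 2 cannot be read, so the earlier pair showed no sensitivity here, whereas compound 3 now shows a large one. Both new steps are minimum sizes only, because their starting compounds sit at a limit: the limit of < 0.01 nM in this assay, at which 2 of the 3 values shown sit.

The compounds shown leave open whether the carbamoyl part or the 4-chlorophenyl part accounts for the loss. A plain carbamoyl group or an amine at this place would help to separate the two.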